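Ethyl in place of fluoromethyl on the urea aryl group

A few compounds are considered here, and "the series" means these few. Any claim that something is new, unique, unknown or untested is made for them only; others in the source may bear on it.

Compound 3 `CNc1cc(Oc2ccc(NC(=O)Nc3cccc(CF)c3)cc2)ncn1` gives 400 nM in an assay on isolated protein for inhibition of serine/threonine-protein kinase TNNI3K (Homo sapiens) (on this read-out higher numbers stand for weaker inhibition and lower numbers for stronger inhibition), the second highest of the three numbers: compound 1 `CNc1cc(Oc2ccc(NC(=O)Nc3cccc(C)c3)cc2)ncn1` gives 1260 nM and compound 2 `CNc1cc(Oc2ccc(NC(=O)Nc3cccc(C(C)(C)C)c3)cc2)ncn1` gives 40 nM. Compound 4 `CCc1cccc(NC(=O)Nc2ccc(Oc3cc(NC)ncn3)cc2)c1` differs from compound 3 by methyl in place of fluoro on a saturated chain carbon bound to an aromatic carbon. Among the compounds with values here, two measured steps bear on this. Growing the alkyl group gave a 32-fold lower number from compound 1 to compound 2 (1.50 log units; beyond the scatter), while adding fluorine to the methyl gave a 3.2-fold lower number from compound 1 to compound 3 (0.50 log units; beyond the scatter); the reverse of that latter step and a modest enlargement of the alkyl group pull in opposite directions, so a step that is small, perhaps within the scatter, is expected. The estimate for compound 4 is therefore 250 nM (range 70 nM to 900 nM), meaning an expected 1.6-fold lower number from compound 3 to compound 4 (0.20 log units; within the scatter).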

Compound 4, half-maximal inhibitory concentration: 200 nM
Estimate against measurement, compound 4: 1.3-fold (0.10 log units) above; measured number inside the range.
By their numbers in this assay, from the lowest: compound 2; then compounds 4 and 3 (each within the scatter of the next); then compound 1.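

In this assay methyl in place of fluoro on this saturated chain carbon gives a 2.0-fold lower number from compound 3 to compound 4 (0.30 log units; within the scatter) so the fluoromethyl and ethyl groups cannot be told apart here. Ethyl stands apart from both methyl and tert-butyl: methyl in place of hydrogen gives a 6.3-fold lower number from compound 1 to compound 4 (0.80 log units; beyond the scatter) and ethyl in place of tert-butyl gives a 5.0-fold higher number from compound 2 to compound 4 (0.70 log units; beyond the scatter) so among these three alkyl groups the number falls stepwise as the group grows. No measurement offered here explains these steps. From the compounds shown here alone, whether isopropyl or cyclopropyl would lie nearer ethyl or tert-butyl stays open, as does the effect of a hydroxymethyl group.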